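Swapping a Hydroxy for a Methyl on the Core

The source may hold more compounds than are shown below. What is called first, only, known or untested is meant among the compounds shown, and "the series" means these compounds.

Compound 1 `CC1(C)Oc2ccc(C#N)cc2[C@@H](n2ccccc2=O)[C@@H]1O` gives 300 nM here
Compound 2 `Cn1nc(O[C@@H]2c3cc(C#N)ccc3OC(C)(C)[C@@]2(C)O)ccc1=O` gives 30 nM here

Among the measured compounds shown here, both values come from a functional assay for inhibition, with Sus scrofa as the target (a lower number here means a stronger inhibitor, a higher number a weaker inhibitor), and are the only measurements so far. Compound 1 has the higher number of the two, which makes it the weaker inhibitor, and its gap to compound 2 lies beyond the usual scatter. These two compounds differ in more than one place, so their gap cannot be pinned on any single change.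

Compound 3 `C[C@H]1[C@H](n2ccccc2=O)c2cc(C#N)ccc2OC1(C)C` stays much closer to compound 1. It keeps the same core but has methyl in place of hydroxy on a saturated ring carbon and no other change.

Compound 1 at 300 nM and compound 2 at 30 nM both carry a hydroxy on that carbon, while compound 3 has none. For the measured compounds named here, no measured pair shows what this swap does, so any forecast is loose. The expected step is a 3.3-fold higher number from compound 1 to compound 3 (0.52 log units; beyond the scatter) toward weaker inhibition in this assay and beyond the scatter, though this is uncertain. For compound 3 the estimated value is 1000 nM with an expected range of 200 nM to 5000 nM in this assay.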

Compound 3, half-maximal inhibitory concentration: > 100000 nM
Compound 3: no number, only a limit; the forecaster's own chance of this, stated with the estimate: 10%; middle value at least 100-fold (2.00 log units) away from the limit.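

Compound 3 gives no number in this assay, only a limit of the assay: the limit of > 100000 nM in this assay, at which 1 of the 3 values shown sits.

Even so, the single swap of hydroxy for methyl on this saturated ring carbon is enough to read a clear result, an at least 330-fold higher number from compound 1 to compound 3 (2.52 log units; beyond the scatter), and that step is large. The change is small on paper, one heavy atom for one heavy atom, with the rest of the core of compound 1 untouched, yet inhibition falls out of the range this assay can read, so on this core the position is highly sensitive to what sits on it. The earlier compounds shown here both carried the hydroxy on that carbon, so only now is there a direct measure of what losing it costs.

Still open, from the compounds shown here alone, is whether another group on this carbon, such as an amine or a methoxy group, would keep any inhibition, which would help show what the hydroxy itself contributes. This step also comes from a single core, so whether it holds alongside the different groups of compound 2 cannot be told from the compounds shown.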